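A double bond enters the ring of compound 2

The source may hold more compounds than are shown below. What is called first, only, known or untested is meant among the compounds shown, and "the series" means these compounds.

Measured in an ADME assay on the whole organism (Rattus norvegicus) for pharmacokinetics, at a dose of 0.5 mg/kg by the intravenous route; a lower number here means slower removal, a higher number faster removal of the compound:
Compound 1 `CNC(=O)Nc1cc(Oc2cncc(OC)c2)c(C2=CCOCC2)cn1`: 41.7 mL/min/kg
Compound 2 `CNC(=O)Nc1cc(Oc2cncc(OC)c2)c([C@H]2CCCOC2)cn1`: 28.3 mL/min/kg

Compound 2, at 28.3 mL/min/kg, stands within the scatter of compound 1. Compound 3 `CNC(=O)Nc1cc(Oc2cncc(OC)c2)c(C2=CCCOC2)cn1` keeps the shared core and changes one group: a group of 6 heavy atoms (5 carbon, 1 oxygen; one six-membered non-aromatic ring with 1 hetero atom) in place of a group of 6 heavy atoms (5 carbon, 1 oxygen; one six-membered non-aromatic ring with 1 hetero atom), on an aromatic carbon. Among the compounds with values here, the only measured step that bears on this is a 1.5-fold lower number from compound 1 to compound 2 (0.17 log units; within the scatter), which also exchanges one such ring for another on an aromatic carbon. That step stays within the scatter, so no step beyond the scatter is expected here in this assay. The estimate amounts to an expected 1.2-fold higher number from compound 2 to compound 3 (0.09 log units; within the scatter). The value expected for compound 3 is 35 mL/min/kg, with an estimated range from 20 mL/min/kg to 60 mL/min/kg.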

Compound 3, clearance: 38.3 mL/min/kg
Estimate against measurement, compound 3: 1.1-fold (0.04 log units) below; the range from low to high includes it.
By their numbers in this assay, from the lowest: compounds 2, 3 and 1 (each within the scatter of the next).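

In this assay, exchanging the oxan-3-yl group for a ring with one double bond gives a 1.4-fold higher number from compound 2 to compound 3 (0.13 log units; within the scatter) and exchanging one double-bond ring for the other gives a 1.1-fold lower number from compound 1 to compound 3 (0.04 log units; within the scatter) on the same aromatic carbon. All three six-membered rings with one ring oxygen therefore stand within the scatter at this position, whether saturated or not. No measurement here offers an explanation for this. The compounds shown leave open whether a ring carrying an amine, such as piperidine, or a carboxylic acid at this position would shift clearance beyond the scatter.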